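Bromo for Chloro on the Aryl Imine

The source may report more compounds than this note shows. Statements on the series, on what has been measured and on what is new or still open speak of the compounds shown alone.

Compound 1, `Cc1nc2c([nH]1)C(=O)/C(=N/c1ccc(F)c(F)c1F)C(Cl)=C2O`, gives 800 nM in a functional assay (Rattus norvegicus) for antiproliferative activity; on this read-out higher numbers stand for weaker inhibition and lower numbers for stronger inhibition.
Compound 2, `Cc1nc2c([nH]1)C(=O)/C(=N/c1cccc(Cl)c1)C(Cl)=C2O`, gives 900 nM in this assay.

Of the compounds shown here, two sharing the same core have been measured. Of the two numbers compound 2 has the higher one, yet its gap to compound 1 lies within the usual scatter, so the two cannot be told apart on this read-out. Compound 3, `Cc1nc2c([nH]1)C(=O)/C(=N/c1cccc(Br)c1)C(Cl)=C2O`, has not yet been measured. It differs from compound 2 in one place: bromo in place of chloro on an aromatic carbon, the position being meta to a large group, so that the 3-chlorophenyl of compound 2 becomes a 3-bromophenyl. For the measured compounds named here, no measured pair shows the effect of this exchange, and the two measured compounds, which carry different substitution on that ring, agree within the scatter. The step of a 1.1-fold lower number from compound 2 to compound 3 (0.05 log units; within the scatter) is therefore expected to stay within the scatter, in either direction. Compound 3 is expected to give 800 nM in this assay, within a range from 350 nM to 1800 nM.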

Compound 3, half-maximal inhibitory concentration: 1000 nM
The estimate for compound 3 lay 1.3-fold (0.10 log units) below the measured number, and the stated range covers the measured number.
By their numbers in this assay, from the lowest: compounds 1, 2 and 3 (each within the scatter of the next).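

Compound 2 and compound 3 form the only pair shown that differs in a single place, and so they isolate one exchange on the aryl ring. In this assay, bromo in place of chloro on this aromatic carbon gives a 1.1-fold higher number from compound 2 to compound 3 (0.05 log units; within the scatter), so this read-out does not separate the two halogens at this position. No data shown offer an account of this outcome.

Going by these compounds, it remains open whether a group of another kind at the same place, such as methoxy, an amine or a carboxylic acid, would move the number beyond the scatter, and whether a plain phenyl without any halogen would do so. Also open, on these data alone, is whether the same exchange would give a similar result on another carbon of that ring or in a different assay.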